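Thiazolyl in place of ethyl on the ring nitrogen

The source may hold more compounds than are shown below. What is called first, only, known or untested is meant among the compounds shown, and "the series" means these compounds.

Measured so far:
- compound 1, `COc1ccc(C)cc1N1C(=O)CSC1c1cccc(C(=O)NCCCCc2ccccc2)c1`: 300 nM
- compound 2, `CCN(CC)c1ccc(N2C(=O)CSC2c2cccc(C(=O)NCCCCc3ccccc3)c2)cc1`: > 1000 nM
- compound 3, `CCN1C(=O)CSC1c1cccc(C(=O)NCCCCc2ccccc2)c1`: > 1000 nM

In a functional assay on HOS-TE85 cells (Homo sapiens) for inhibition, read by CCK-8 assay, with a stated time of 72 h (a lower number here means a stronger inhibitor, a higher number a weaker inhibitor), compound 3 sits at a limit, > 1000 nM, so only an upper bound on its potency is known. The same limit holds for compound 2, (the limit of > 1000 nM in this assay, at which 2 of the 3 values shown sit). Compound 4, `O=C(NCCCCc1ccccc1)c1cccc(C2SCC(=O)N2c2nccs2)c1`, differs from compound 3 in one place: 1,3-thiazol-2-yl in place of ethyl on an amide-type nitrogen in a ring.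

Two measured steps change the same position. From the aryl group of compound 1 to the ethyl of compound 3 the number rises, an at least 3.3-fold higher number from compound 1 to compound 3 (0.52 log units; beyond the scatter), so the aryl group is the better of the two here. Yet the other aryl group gives no such gain: an at least 3.3-fold higher number from compound 1 to compound 2 (0.52 log units; beyond the scatter). The step that the two limits leave unreadable from compound 2 to compound 3 cannot be read, as both values are limits. A five-membered heteroaryl ring on the ring nitrogen may thus recover some potency, but the limits leave that uncertain.

Compound 4 is expected to land near 800 nM, within 250 nM to 3000 nM, which means an estimated step of an at least 1.2-fold lower number from compound 3 to compound 4 (0.09 log units; that floor lies within the scatter) in this assay.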

Compound 4, half-maximal inhibitory concentration: > 1000 nM
Compound 4: only a limit was reported; the forecaster's own chance of this, stated with the estimate: 45%; middle value at least 1.2-fold (0.09 log units) from the limit.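

In this assay compound 4 gives > 1000 nM, which is a limit and not a number. A five-membered aromatic ring on this nitrogen therefore does not bring the value into the measurable range, and setting 1,3-thiazol-2-yl in place of 2-methoxy-5-methylphenyl gives an at least 3.3-fold higher number from compound 1 to compound 4 (0.52 log units; beyond the scatter). The steps among compound 2, compound 3 and compound 4 cannot be read, so among the groups shown only the 2-methoxy-5-methylphenyl of compound 1 gives a measured value in this assay: the limit of > 1000 nM in this assay, at which 3 of the 4 values shown sit.

From the compounds shown here alone, it remains open how far compound 2, compound 3 and compound 4 differ beyond the limit, and whether the methoxy group, the methyl group or both matter in compound 1. A plain phenyl or a pyridyl ring at this position would help to separate these possibilities.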